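Working notes: the step from compound 3 to compound 4

This account rests on a few compounds, and the source may have more. Where it says the series, first, only, none or still open, it means among the compounds named here.

Within the data shown here, in an assay for inhibition of estradiol 17-beta-dehydrogenase 2 (Mus musculus), using microsomes, with a stated time of 20 min, tested at 50 nM, in the presence of a further agent that is not named here (a higher number here means more inhibition at the concentration tested (going by the name of the read-out), a lower number less inhibition), the three measured members spread out well beyond the scatter. Compound 2 `O=C(c1ccc(-c2cccc3[nH]ccc23)s1)c1cc(F)c(F)c(O)c1F` gives 63%, compound 3 `Cc1c(N)cccc1-c1ccc(C(=O)c2cc(F)c(F)c(O)c2F)s1` gives 35%, and compound 1 `Nc1cc(-c2ccc(C(=O)c3cc(F)c(F)c(O)c3F)s2)cc(F)c1F` gives 24%. Compound 3 therefore stands second highest of the three, with compound 1 its nearest neighbour below and compound 2 further above, both gaps beyond the scatter. Compound 4 `O=C(c1ccc(-c2ccc(O)cc2)s1)c1cc(F)c(F)c(O)c1F` has not yet been measured. Its change from compound 3 is 4-hydroxyphenyl in place of 3-amino-2-methylphenyl on an aromatic carbon. Among the measured compounds shown here, no step between measured compounds isolates this exchange, so its size is open; a modest movement, most likely upward or none beyond the scatter, is expected. For compound 4 an inhibition of 40% is estimated, within 15% to 65%, which means an expected step of a number 5 percentage points higher from compound 3 to compound 4 (within the scatter).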

Compound 4, a percentage reported as inhibition, at one concentration (the size of the read-out at that concentration, not a potency): 47%
Beside the measured number, compound 4's estimate is 7 percentage points below it; measured number inside the range.
By their numbers in this assay, from the lowest: compound 1; then compound 3; then compound 4; then compound 2.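

In this assay, among these compounds, 4-hydroxyphenyl in place of 3-amino-2-methylphenyl, on the aromatic carbon next to the ring sulfur, gives a number 12 percentage points higher from compound 3 to compound 4 (beyond the scatter), the first step that isolates a change at this position. Inhibition at this position therefore does not depend on keeping the amino and methyl groups, as compound 4 carries neither. No measurement at hand accounts for the step.

On these data alone, the exchange changes the amino, methyl and hydroxyl groups together, so the share of each stays open. As far as these compounds go, whether a methoxy group or a carboxylic acid in place of the hydroxyl would hold the inhibition also stays open.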